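Fluoro to Methoxy on Two Related Cores

This account rests on a few compounds, and the source may have more. Where it says the series, first, only, none or still open, it means among the compounds named here.

Compound 1 `CC(=O)c1cc(-c2ccccc2)cc2cc(-c3ccc(F)cc3)[nH]c12`, compound 2 `COc1ccc(-c2cc3cc(-c4ccccc4)cc(C(C)=O)c3[nH]2)cc1` and compound 3 `CC(=O)c1cc(/C=C/c2ccc(F)cc2)cc2cc(-c3ccc(F)cc3)[nH]c12` were tested in a functional assay on HeLa cells (Homo sapiens) for cytotoxicity, read by MTT assay, with a stated time of 2 days; on this read-out lower numbers stand for higher toxicity in this test and higher numbers for lower toxicity in this test. Compound 1 gives > 100000 nM, which is a limit of the assay rather than a number. Compound 2 gives 18900 nM, and compound 3 gives 5680 nM. Compound 1 and compound 2 differ by methoxy in place of fluoro on an aromatic carbon, a change that brought an at least 5.2-fold lower number from compound 1 to compound 2 (0.72 log units; beyond the scatter). The cores of compound 1 and compound 3 differ by 2-(4-fluorophenyl)ethenyl in place of phenyl on an aromatic carbon, which brought an at least 17-fold lower number from compound 1 to compound 3 (1.24 log units; beyond the scatter). Compound 4 `COc1ccc(-c2cc3cc(/C=C/c4ccc(F)cc4)cc(C(C)=O)c3[nH]2)cc1` has not yet been measured; it repeats the same change on the core of compound 3, namely (methoxy in place of fluoro on an aromatic carbon), at the same place. That earlier step is only a bound because compound 1 sits at the limit of > 100000 nM in this assay, at which 1 of the 3 values shown sits. A smaller move is expected this time, a 2.3-fold lower number from compound 3 to compound 4 (0.36 log units; beyond the scatter), resting on compound 3 giving 5680 nM. Compound 4 is expected to give 2500 nM in this assay.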

Compound 4, concentration lethal to 50% of the cells: 8770 nM
For compound 4 the middle estimate is 3.5-fold (0.55 log units) below the measured one, outside the stated range (above it).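

Methoxy in place of fluoro does not repeat its earlier effect in this assay: a 1.5-fold higher number from compound 3 to compound 4 (0.19 log units; within the scatter) stays within the scatter, and the two steps differ: the same change on two cores in this assay, an at least 5.2-fold lower number (0.72 log units; beyond the scatter) from compound 1 to compound 2 and a 1.5-fold higher number (0.19 log units; within the scatter) from compound 3 to compound 4, at least 8.1-fold (0.91 log units) apart, beyond the scatter of two such steps

With methoxy already present, 2-(4-fluorophenyl)ethenyl in place of phenyl brings a 2.2-fold lower number from compound 2 to compound 4 (0.33 log units; beyond the scatter), a smaller step than the one seen with fluoro present: the same change on two cores in this assay, an at least 17-fold lower number (1.24 log units; beyond the scatter) from compound 1 to compound 3 and a 2.2-fold lower number (0.33 log units; beyond the scatter) from compound 2 to compound 4, at least 8.1-fold (0.91 log units) apart, beyond the scatter of two such steps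

Compound 1 sits at a limit of the assay, so both gaps are minimum sizes, and these four compounds show that each step depends on the core without showing why: the limit of > 100000 nM in this assay, at which 1 of the 4 values shown sits.

The compounds shown leave open how other groups at the same place, such as an amine or a carboxylic acid, would behave on these two cores. They also leave open whether a longer chain in place of methoxy would follow either step.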